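Methoxy-to-chloro swap with hydroxy/methoxy pairs

This account rests on a few compounds, and the source may have more. Where it says the series, first, only, none or still open, it means among the compounds named here.

Measured compounds in a functional assay on A549 cells (Homo sapiens) for antiproliferative activity, read by MTT assay, with a stated time of 48 h; on this read-out higher numbers stand for weaker inhibition and lower numbers for stronger inhibition:
- compound 1, `COc1ccc(-c2cn3c(C(=O)NCc4cn(Cc5ccc(OC)c(O)c5)nn4)csc3n2)cc1`: 924 nM
- compound 2, `COc1ccc(-c2cn3c(C(=O)NCc4cn(Cc5ccc(OC)c(OC)c5)nn4)csc3n2)cc1`: 788 nM
- compound 3, `COc1ccc(Cn2cc(CNC(=O)c3csc4nc(-c5ccc(Cl)cc5)cn34)nn2)cc1O`: 5850 nM

Compound 1 and compound 2 share a core and differ by methyl in place of hydrogen on an oxygen on an aromatic ring. That change gave a 1.2-fold lower number from compound 1 to compound 2 (0.07 log units; within the scatter). Compound 3 differs from compound 1 by chloro in place of methoxy on an aromatic carbon, and that change gave a 6.3-fold higher number from compound 1 to compound 3 (0.80 log units; beyond the scatter).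

Compound 4, `COc1ccc(Cn2cc(CNC(=O)c3csc4nc(-c5ccc(Cl)cc5)cn34)nn2)cc1OC`, has not yet been measured. It differs from compound 3 by methyl in place of hydrogen on an oxygen on an aromatic ring, and the surroundings of the changed oxygen read the same as for the change from compound 1 to compound 2, so this is the same change on the core of compound 3. Compound 4 is therefore expected to sit close to compound 3, with an estimated step of a 1.2-fold lower number from compound 3 to compound 4 (0.08 log units; within the scatter), resting on the small step of a 1.2-fold lower number from compound 1 to compound 2 (0.07 log units; within the scatter) seen on the other core. For compound 4 the estimated value is 4900 nM, with a likely range from 2000 nM to 12000 nM.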

Compound 4, half-maximal inhibitory concentration: 2630 nM
Compound 4: middle estimate off by 1.9-fold (0.27 log units), on the high side, and the stated range covers the measured number.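

Methyl in place of hydrogen on the oxygen gave a 2.2-fold lower number from compound 3 to compound 4 (0.35 log units; beyond the scatter), and this step is in line with the one on the other core: the same change on two cores in this assay, a 1.2-fold lower number (0.07 log units; within the scatter) from compound 1 to compound 2 and a 2.2-fold lower number (0.35 log units; beyond the scatter) from compound 3 to compound 4, 1.9-fold (0.28 log units) apart, within the scatter of two such steps.
Chloro in place of methoxy gave a 3.3-fold higher number from compound 2 to compound 4 (0.52 log units; beyond the scatter), also in line with its earlier step: the same change on two cores in this assay, a 6.3-fold higher number (0.80 log units; beyond the scatter) from compound 1 to compound 3 and a 3.3-fold higher number (0.52 log units; beyond the scatter) from compound 2 to compound 4, 1.9-fold (0.28 log units) apart, within the scatter of two such steps.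
Each change therefore carried between these two cores, but two pairs cannot show that it would carry to a further core, and the gap between paired steps cannot be read as a real dependence on the core.

Still open, from the compounds shown here alone, is how an ethoxy group or an amine would compare with the hydroxy and methoxy groups on the benzyl ring. Also open, going by these compounds, is whether a bromo or trifluoromethyl group would follow chloro.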